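The source may hold more compounds than are shown below. What is called first, only, known or untested is meant among the compounds shown, and "the series" means these compounds.

Measured compounds:
compound 1 `CCOC(=O)C(Sc1nc(Cl)cc(Nc2cccc(C)c2C)n1)c1ccccc1`, in an assay for inhibition of Polyunsaturated fatty acid 5-lipoxygenase (Homo sapiens), tested at 1 uM (a higher number here means a weaker effect of the compound at the concentration tested, a lower number a stronger effect), compound 1 gives 53.1%;
compound 2 `CCOC(=O)C(C)Sc1nc(Cl)cc(Nc2ccc3ncccc3c2)n1`, in this assay compound 2 gives "not active" (no number reported).

Compound 2 thus stands with no number at all: it was reported as inactive in this assay, so no single value marks its place. The step to compound 3 `CCOC(=O)C(Sc1nc(Cl)cc(Nc2ccc3ncccc3c2)n1)c1ccccc1` changes one spot: phenyl in place of methyl on a saturated chain carbon bound to a carbonyl carbon and a sulfur. Going by the values given here, compound 1, which carries phenyl at the same spot, does show measurable inhibition, so a stronger effect than for compound 2 is expected, meaning a lower number, though with no measured step the size is open. Compound 3 is expected to give about 75%, somewhere between 50% and 100%.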

Compound 3, a percentage reported as activity, at one concentration (the size of the read-out at that concentration, not a potency): 52.7%
Beside the measured number, compound 3's estimate is 22.3 percentage points above it; low and high end bracket the measured number.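

Phenyl in place of methyl on the saturated chain carbon bound to a carbonyl carbon and a sulfur gives the quinolin-6-yl series a measurable read-out in this assay: compound 2 is reported as not active, whereas compound 3 gives 52.7% as a number. Quinolin-6-yl in place of 2,3-dimethylphenyl on the nitrogen gives a number 0.4 percentage points lower from compound 1 to compound 3 (within the scatter) and so stays within the scatter. No measurement shown offers a reason for either result. Still open, going by these compounds, is whether benzyl or cyclohexyl at that chain carbon would give a similar read-out, and whether a carboxylic acid or an amide could stand in place of the ethyl ester.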